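Shortening the chain to the sulfonyl in a pyridinium oxime

The source may hold more compounds than are shown below. What is called first, only, known or untested is meant among the compounds shown, and "the series" means these compounds.

Of the compounds shown here, three of one series have been measured in a physicochemical assay for lipophilicity; on this read-out higher numbers stand for higher lipophilicity and lower numbers for lower lipophilicity. Compound 1 `C[n+]1ccn(COCCCCS(C)(=O)=O)c1/C=N/O` gives -3.11 in this assay, the lowest of the three numbers. Compound 2 `C[n+]1ccn(CCC[n+]2cccc(C(=O)c3ccccc3)c2)c1/C=N/O` stands nearest to it, with -2.62, a gap beyond the scatter of repeated measurements. Compound 3 `CN(CCOCCn1cc[n+](C)c1/C=N/O)S(=O)(=O)C(F)(F)F` lies furthest away, at -1.63, again beyond the scatter. No pair among these three differs in only one place, so none of these gaps can be tied to a single structural change.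

Compound 4 `CCS(=O)(=O)CCOCn1cc[n+](C)c1/C=N/O` has not yet been measured. It differs from compound 1 in one place: ethylsulfonyl in place of 2-(methylsulfonyl)ethyl on a saturated chain carbon, two bonds along the chain from an oxygen on a saturated carbon. The group that leaves is counted as one heavy atom larger than the group that enters, while the numbers of donors and acceptors and the absence of charge stay as counted.

Going by the values given here, with no measured step of this kind among the three compounds, the expectation rests on the count alone. A loss of one chain carbon is expected to lower lipophilicity only slightly, at the edge of the scatter; the step expected from compound 1 to compound 4 is a number 0.19 log units lower from compound 1 to compound 4 (within the scatter). Compound 4 is therefore estimated at -3.3, within a range from -3.9 to -2.7.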

Compound 4, distribution coefficient: < -2.7
Compound 4 ended at the assay's limit (the forecaster's own chance of this, stated with the estimate: 5%); the middle value lies beyond the limit too.
By their numbers in this assay, from the lowest: compound 1; then compound 2; then compound 3.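

In this assay compound 4 gives < -2.7, which is a limit of the assay and not a number: the limit of < -2.7 in this assay, at which 1 of the 4 values shown sits. Going by these compounds alone, no step from compound 1 to compound 4 can therefore be read. The compounds shown leave open how far, if at all, ethylsulfonyl in place of 2-(methylsulfonyl)ethyl moves the number on this read-out.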